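The source may hold more compounds than are shown below. What is called first, only, known or untested is meant among the compounds shown, and "the series" means these compounds.

Compound 1 `Cc1ccc(S(=O)(=O)/C(=C/c2ccc(Cl)cc2)C(=O)c2ccc(Cl)cc2)cc1` is the reference point of this account. In a functional assay on DU-145 cells (Homo sapiens) for inhibition, read by trypan blue exclusion, with a stated time of 96 h (a higher number here means a weaker inhibitor of growth, a lower number a stronger inhibitor of growth), compound 1 gives 1000 nM, the lowest of the two numbers recorded so far. Among the compounds with values here, its only measured neighbour, compound 2 `Cc1ccc(CS(=O)(=O)/C(=C/c2ccc(Cl)cc2)C(=O)c2ccc(Cl)cc2)cc1`, gives 25000 nM in this assay, and the step of a 25-fold higher number from compound 1 to compound 2 (1.40 log units; beyond the scatter) concerns the group on the sulfonyl sulfur. Compound 3 `Cc1ccc(S(=O)(=O)/C(=C/c2cc(C)cc(C)c2)C(=O)c2ccc(Cl)cc2)cc1` differs from compound 1 in another part of the core of compound 1: 3,5-dimethylphenyl in place of 4-chlorophenyl on a double-bonded chain carbon bound to a double-bonded chain carbon. Within the data shown here, no measured step touches the group on the double-bonded chain carbon, so the one large step recorded offers no guide to this change, and the expectation rests on the value of compound 1 alone. For compound 3 the expected step is a 1.5-fold higher number from compound 1 to compound 3 (0.18 log units; within the scatter) in this assay, none beyond the scatter. Compound 3 is therefore estimated at 1500 nM in this assay, within a range from 400 nM to 6000 nM.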

Compound 3, concentration for 50% growth inhibition: 1000 nM
Beside the measured number, compound 3's estimate is 1.5-fold (0.18 log units) above it; low and high end bracket the measured number.
By their numbers in this assay, from the lowest: compounds 1 and 3 (each within the scatter of the next); then compound 2.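

In this assay, placing 3,5-dimethylphenyl in place of 4-chlorophenyl on a double-bonded chain carbon bound to a double-bonded chain carbon gives no change at the digits printed from compound 1 to compound 3 (within the scatter), so the chlorine can be exchanged for two methyl groups at this position without a step beyond the scatter. The one large step so far, a 25-fold higher number from compound 1 to compound 2 (1.40 log units; beyond the scatter), concerns the group on the sulfonyl sulfur, so of the two places examined, only that one has shown a step beyond the scatter. Nothing at hand explains why the two aryl groups give the same reading.

A single pair at this position leaves open whether a methoxy group, an amine or a carboxylic acid on that phenyl ring would read the same. From the compounds shown here alone, it also remains open whether 3,5-dimethylphenyl would give a similar reading with 4-methylbenzyl on the sulfonyl sulfur.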